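The source may report more compounds than this note shows. Statements on the series, on what has been measured and on what is new or still open speak of the compounds shown alone.

Measured in a physicochemical assay for solubility, at pH 7.4; a higher number here means a more soluble compound, a lower number a less soluble compound:
- compound 1 `CNC1(C)CN(c2cc3c(cc2F)c(=O)c(C(=O)O)cn3C2CC2)C1`: 0.7 ug/mL
- compound 2 `C[C@H]1[C@H](N)CN1c1cc2c(cc1F)c(=O)c(C(=O)O)cn2C1CC1`: 9.9 ug/mL
- compound 3 `C[C@@H]1[C@@H](N(C)C)CN1c1cc2c(cc1F)c(=O)c(C(=O)O)cn2C1CC1`: 96.3 ug/mL

Compound 2, at 9.9 ug/mL, stands in the middle of these three. Below it lies compound 1, as a 14-fold higher number from compound 1 to compound 2 (1.15 log units; beyond the scatter) shows, and above it lies compound 3, as a 9.7-fold higher number from compound 2 to compound 3 (0.99 log units; beyond the scatter) shows.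

The next compound, compound 4 `C[C@H]1[C@H](N)CN1c1c(F)cc2c(=O)c(C(=O)O)cn(C3CC3)c2c1Cl`, keeps the four-membered ring group of compound 2 and changes the shared core instead: chloro in place of hydrogen on an aromatic carbon. In words, this is chloro in place of hydrogen on an aromatic carbon.

For the measured compounds named here, no measured step touches that place, since all three exchange the four-membered ring group. Going by the values given here, with a 140-fold higher number from compound 1 to compound 3 (2.14 log units; beyond the scatter) as the widest, they show only that numbers in this set can move far, so they give no direct guide and argue for a wide range. The expected change, a 1.4-fold lower number from compound 2 to compound 4 (0.15 log units; within the scatter), is therefore small and slightly downward, with no step beyond the scatter expected. Compound 4 is estimated at 7 ug/mL, within an expected range of 1.5 ug/mL to 30 ug/mL.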

Compound 4, solubility: 12 ug/mL
The estimate for compound 4 lay 1.7-fold (0.23 log units) below the measured number; the range from low to high includes it.
By their numbers in this assay, from the lowest: compound 1; then compounds 2 and 4 (each within the scatter of the next); then compound 3.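

In this assay, for the compounds shown here, the step of a 1.2-fold higher number from compound 2 to compound 4 (0.08 log units; within the scatter) gives the first reading at this place on the shared core, an aromatic carbon ortho to a group of 6 heavy atoms and meta to a fluoro group. Going by these compounds alone, all the earlier steps exchanged the four-membered ring group and came out beyond the scatter, whereas chloro in place of hydrogen here stays within it, at least for this one pair. Nothing measured here offers an explanation for this result.

Going by these compounds, whether another group at this place, such as methoxy or a nitrile, would also stay within the scatter remains open. On these data alone, it is also open whether chloro would behave the same way alongside the four-membered ring groups of compound 1 or compound 3.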